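The compounds below may be only part of what the source reports. "The series", "measured", "known", "first", "only" and "open" are said of these compounds alone.

Measured so far:
- compound 1 `O=C(/C(=C\c1ccc(Cl)cc1)SCc1ccc(F)cc1)c1ccc(Cl)cc1` gives 10000 nM
- compound 2 `Cc1ccc(S/C(=C/c2c[nH]c3ccccc23)C(=O)c2ccc(Cl)cc2)cc1` gives 10000 nM

In a functional assay on DU-145 cells (Homo sapiens) for inhibition, read by trypan blue exclusion, with a stated time of 96 h (on this read-out lower numbers stand for stronger inhibition of growth and higher numbers for weaker inhibition of growth), compound 2 stands at 10000 nM, level with compound 1 within the scatter and with no other measured neighbour. The next compound to be tested is compound 3 `Cc1ccc(S/C(=C/c2ccc(Cl)cc2)C(=O)c2ccc(Cl)cc2)cc1`, which differs from compound 2 in one place: 4-chlorophenyl in place of 1H-indol-3-yl on a double-bonded chain carbon bound to a double-bonded chain carbon. This puts 4-chlorophenyl in place of 1H-indol-3-yl on a double-bonded chain carbon bound to a double-bonded chain carbon.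

For the measured compounds named here, no measured pair isolates a single change, so the size of this step has no direct precedent. The nearest evidence is indirect. Compound 1 carries 4-chlorophenyl at that place, though it also differs from compound 3 elsewhere. Compound 1 gives 10000 nM. Compound 2 carries 1H-indol-3-yl there and gives 10000 nM. On that basis, no step beyond the scatter is expected in this assay, in either direction.

The expected change is no change at the digits printed from compound 2 to compound 3 (within the scatter). For compound 3 the estimated value is 10000 nM, with an expected range of 3000 nM to 30000 nM.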

Compound 3, concentration for 50% growth inhibition: 10000 nM
Compound 3: the middle estimate sits on the measured number at the digits printed; the range from low to high includes it.
By their numbers in this assay, from the lowest: compounds 1, 2 and 3 (each within the scatter of the next).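

In this assay, the change at a double-bonded chain carbon bound to a double-bonded chain carbon gives no change at the digits printed from compound 2 to compound 3 (within the scatter): this first single-place comparison at this position shows that replacing 1H-indol-3-yl, with its hydrogen-bond donor and five-membered aromatic ring, by 4-chlorophenyl leaves the read-out unmoved. The sulfur is a second place where a single exchange moves nothing, with 4-methylphenyl in place of 4-fluorobenzyl giving no change at the digits printed from compound 1 to compound 3 (within the scatter) and compound 3 at 10000 nM. Nothing available explains why neither exchange shifts the number.

All three compounds stand at one level, so the compounds shown do not tell whether either place can carry a group that moves the number in this assay. As far as these compounds go, a carboxylic acid or an amine in place of 4-chlorophenyl on that double-bonded chain carbon, or a longer chain on the sulfur, remains open, and a step beyond the scatter from such a group would be the first sign that either place matters.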